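A few compounds are considered here, and "the series" means these few. Any claim that something is new, unique, unknown or untested is made for them only; others in the source may bear on it.

Measured compounds:
- compound 1, `CSc1cnc2ccccc2c1[Se]CC#CCOC(=O)c1ccc(C(=O)O)cc1`: 4 ug/mL
- compound 2, `OCC#CCSc1cnc2ccccc2c1SCC#CCCl`: 3.3 ug/mL

Both numbers come from a functional assay on CCRF-CEM cells (Homo sapiens) for antiproliferative activity, with a stated time of 72 h; on this read-out lower numbers stand for stronger inhibition and higher numbers for weaker inhibition. Compound 1 and compound 2 lie within the scatter of each other, so the two show no separation on this assay.

Compound 3, `CSc1cnc2ccccc2c1[Se]CC#CCOC(=O)c1ccccc1`, is not yet measured. It differs from compound 1 by hydrogen in place of carboxy on an aromatic carbon. Among the measured compounds shown here, no pair of measured compounds shows this change, so nothing gives its size. The step from compound 1 to compound 3 is expected to be small, a 1.3-fold lower number from compound 1 to compound 3 (0.12 log units; within the scatter), and not beyond the scatter in either direction. For compound 3 the estimate is 3 ug/mL, with a range from 0.9 ug/mL to 10 ug/mL.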

Compound 3, concentration for 50% inhibition: 1.9 ug/mL
For compound 3 the middle estimate is 1.6-fold (0.20 log units) above the measured one; the range from low to high includes it.
By their numbers in this assay, from the lowest: compounds 3, 2 and 1 (each within the scatter of the next, the first and the last beyond it).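

In this assay, among the compounds shown here, the change from 4-carboxyphenyl to phenyl gives the first readable step, a 2.1-fold lower number from compound 1 to compound 3 (0.32 log units; beyond the scatter), and it is a modest one. The carboxy at this position is therefore not required for activity on this read-out, and its removal goes with a stronger number rather than a loss. No measurement in hand bears on the reason for this step. Open, on these data alone, is how an amine or a methyl ester at this position on the phenyl would read, and whether anything larger than hydrogen is tolerated there.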